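The compounds below may be only part of what the source reports. "The series", "measured", "known", "first", "only" and "open" are said of these compounds alone.

Of the compounds shown here, three have been measured for inhibition of the whole organism. Compound 1 `N=C(N)Nc1ccc(C(=O)NCC(=O)N2CCN(CC(=O)O)C(=O)[C@@H]2CNC(=O)c2ccc(NC(=N)N)cc2)cc1` gives 140 nM in a functional assay for inhibition, with Cavia porcellus as the target; a lower number here means a stronger inhibitor, a higher number a weaker inhibitor. Compound 3 `N=C(N)Nc1ccc(C(=O)NC[C@H]2C(=O)N(CC(=O)O)CCN2C(=O)CNC(=O)c2ccc(C(=N)N)cc2)cc1` gives 85 nM in this assay, and compound 2 `N=C(N)Nc1ccc(C(=O)NCCC[C@H]2C(=O)N(CC(=O)O)CCN2C(=O)CNC(=O)c2ccc(NC(=N)N)cc2)cc1` gives 51 nM in this assay. Going by the values given here, the only change that is seen twice is a group of 3 heavy atoms (1 carbon, 2 nitrogen; no ring) in place of a group of 4 heavy atoms (1 carbon, 3 nitrogen; no ring), on an aromatic carbon: it gave a 1.6-fold lower number from compound 1 to compound 3 (0.22 log units; within the scatter). How the core of compound 1 differs from the core of compound 2 is not broken down here. Compound 4 `N=C(N)Nc1ccc(C(=O)NCCC[C@H]2C(=O)N(CC(=O)O)CCN2C(=O)CNC(=O)c2ccc(C(=N)N)cc2)cc1` carries the same change on the core of compound 2, namely (a group of 3 heavy atoms (1 carbon, 2 nitrogen; no ring) in place of a group of 4 heavy atoms (1 carbon, 3 nitrogen; no ring), on an aromatic carbon). Because compound 1 to compound 3 gave a 1.6-fold lower number from compound 1 to compound 3 (0.22 log units; within the scatter), a step of similar size is expected, and compound 2 to compound 4 is estimated at a 1.6-fold lower number from compound 2 to compound 4 (0.20 log units; within the scatter). Compound 4 is therefore expected to give about 32 nM in this assay, likely between 15 nM and 70 nM.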

Compound 4, half-maximal inhibitory concentration: 19 nM
Estimate against measurement, compound 4: 1.7-fold (0.23 log units) above; the range from low to high includes it.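

The same change, a group of 3 heavy atoms (1 carbon, 2 nitrogen; no ring) in place of a group of 4 heavy atoms (1 carbon, 3 nitrogen; no ring), on an aromatic carbon, gave a 2.7-fold lower number from compound 2 to compound 4 (0.43 log units; beyond the scatter) in this assay. Set beside the earlier step, it carried over between the two cores without a difference beyond the scatter: the same change on two cores in this assay, a 1.6-fold lower number (0.22 log units; within the scatter) from compound 1 to compound 3 and a 2.7-fold lower number (0.43 log units; beyond the scatter) from compound 2 to compound 4, 1.6-fold (0.21 log units) apart, within the scatter of two such steps This shows agreement on these two cores only, and it does not show that the change would behave alike on any other core, nor why the number falls.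

The compounds shown leave open how an amine or a nitrile on that aromatic carbon would compare. They also leave open whether the step keeps its size with a longer chain on the core.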